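Series notes: trifluoromethyl on the terminal phenyl of compound 1

The compounds below may be only part of what the source reports. "The series", "measured", "known", "first", "only" and "open" are said of these compounds alone.

Measured so far:
compound 1, `COc1cc2c(Oc3ccc(NC(=O)c4nn(-c5ccccc5)c(=O)cc4C)cc3F)ccnc2cc1OCCCN1CCCC1` — 1100 nM
compound 2, `COc1cc2c(Oc3ccc(NC(=O)c4nn(-c5ccccc5)c(=O)cc4C)cc3F)ccnc2cc1OCCCN1CCN(C)CC1` — 2120 nM

Among the compounds with values here, in a functional assay on U-87MG ATCC cells (Homo sapiens) for inhibition, read by MTT assay, with a stated time of 72 h (a lower number here means a stronger inhibitor, a higher number a weaker inhibitor), compound 1 gives 1100 nM, the lower of the two numbers measured, though the only measured step, a 1.9-fold higher number from compound 1 to compound 2 (0.28 log units; within the scatter), lies within the scatter, so the two compounds cannot be separated on these data. That step swaps 4-methylpiperazin-1-yl for pyrrolidin-1-yl on a saturated chain carbon, three bonds along the chain from an oxygen on an aromatic ring.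

Compound 3, `COc1cc2c(Oc3ccc(NC(=O)c4nn(-c5ccccc5C(F)(F)F)c(=O)cc4C)cc3F)ccnc2cc1OCCCN1CCCC1`, keeps the chain and the pyrrolidin-1-yl of compound 1 and differs from it elsewhere: trifluoromethyl in place of hydrogen on an aromatic carbon. The trifluoromethyl enters on an aromatic carbon of a six-membered aromatic ring of carbon only, ortho to a large group; cut one bond further out the change reads phenyl to 2-(trifluoromethyl)phenyl. Within the data shown here, no measured step touches this ring, so nothing measured bears directly on the change; the one step that exists, from compound 1 to compound 2, altered a different part and stayed within the scatter.

Among the measured compounds shown here, with no precedent, the expected step is no change at the digits printed from compound 1 to compound 3 (within the scatter), meaning none beyond the scatter. Compound 3 is therefore estimated at 1100 nM in this assay, with a range of 400 nM to 3500 nM.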

Compound 3, half-maximal inhibitory concentration: 1010 nM
Compound 3: the middle estimate sits 1.1-fold (0.04 log units) above what was measured; the range from low to high includes it.
By their numbers in this assay, from the lowest: compounds 3, 1 and 2 (each within the scatter of the next, the first and the last beyond it).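

In this assay the phenyl of compound 1 accepts trifluoromethyl in place of hydrogen on an aromatic carbon, ortho to a large group, with a 1.1-fold lower number from compound 1 to compound 3 (0.04 log units; within the scatter), and this is the only reading on that ring among the compounds shown. Together with the step at the other end of the molecule, a 1.9-fold higher number from compound 1 to compound 2 (0.28 log units; within the scatter), it means that neither of the two places varied so far has separated a compound from compound 1, although here 4 heavy atoms, 1 carbon and 3 fluorine, enter where only a hydrogen stood. No measured information is available to account for this absence of separation.

Open, going by these compounds, is whether this carbon stays as undiscriminating with other groups, such as a single fluorine, a methoxy group, a nitrile, an amine or a carboxylic acid, or whether one of these would move the number beyond the scatter. Also open, on these data alone, are the same trifluoromethyl on the other carbons of that ring, and 2-(trifluoromethyl)phenyl paired with the 4-methylpiperazin-1-yl chain of compound 2.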